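Hydroxyl shift on the anilino enones: compound 3 to 4

The source may hold more compounds than are shown below. What is called first, only, known or untested is meant among the compounds shown, and "the series" means these compounds.

Measured in a functional assay on K562 cells (Homo sapiens) for cytotoxicity, read by trypan blue exclusion, with a stated time of 96 h (a lower number here means a stronger inhibitor, a higher number a weaker inhibitor), so far
compound 1 `COc1cc(C(=O)/C=C\Nc2ccccc2O)c(Br)c(OC)c1OC` gives 200 nM
compound 2 `COc1cc(OC)c(N/C=C\C(=O)c2c(OC)cc(OC)cc2OC)c(OC)c1` gives 50000 nM
compound 3 `COc1cc(C(=O)/C=C\Nc2ccccc2O)cc(OC)c1OC` gives 500 nM

Compound 3 at 500 nM has the second highest of the three numbers, with compound 1 lower and compound 2 far higher. The change to compound 4 `COc1cc(C(=O)/C=C\Nc2cccc(O)c2)cc(OC)c1OC` is 3-hydroxyphenyl in place of 2-hydroxyphenyl on an amine nitrogen and reads in words as 3-hydroxyphenyl in place of 2-hydroxyphenyl on an amine nitrogen. Going by the values given here, the only measured step between compounds differing in one place is a 2.5-fold higher number from compound 1 to compound 3 (0.40 log units; beyond the scatter) and it concerns hydrogen in place of bromo on an aromatic carbon, so it gives a scale but no direction for this change. Compound 2 differs from compound 3 in more than one place and offers no clean comparison. Among the compounds with values here, the expected step in this assay is a 2.4-fold higher number from compound 3 to compound 4 (0.38 log units; beyond the scatter) and this modest rise is a judgement, as no measured pair tests the hydroxyl shift. Compound 4 is estimated at 1200 nM with an expected range of 250 nM to 8000 nM in this read-out.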

Compound 4, half-maximal inhibitory concentration: 500 nM
Beside the measured number, compound 4's estimate is 2.4-fold (0.38 log units) above it; measured number inside the range.
By their numbers in this assay, from the lowest: compound 1; then compounds 3 and 4 (each within the scatter of the next); then compound 2.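

In this assay, going by these compounds alone, the shift from 2-hydroxyphenyl to 3-hydroxyphenyl on the amine nitrogen gives no change at the digits printed from compound 3 to compound 4 (within the scatter), the first reading at this position, since the only earlier single-place step, a 2.5-fold higher number from compound 1 to compound 3 (0.40 log units; beyond the scatter), concerns hydrogen in place of bromo on an aromatic carbon. For this pair, then, the hydroxyl can occupy either of the two printed placements with no separation in the cytotoxicity read-out, whereas the bromo step on the other side of the molecule lies beyond the scatter. No available data bear on why the two compounds read alike.

Still open, as far as these compounds go, is whether the hydroxyl matters at all, which an unsubstituted phenyl, a methoxy group, an amine or a carboxylic acid at the same place would test. Also open, from the compounds shown here alone, is whether the bromo step carries over to the 3-hydroxyphenyl compounds.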